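The source may hold more compounds than are shown below. What is called first, only, known or untested is meant among the compounds shown, and "the series" means these compounds.

Measured so far:
compound 1, `O=C1CNc2nc(Nc3ccccc3)ncc2N1` — > 100000 nM
compound 2, `COc1cccc(Nc2ncc3c(n2)NCC(=O)N3)c1` — > 100000 nM

In a functional assay on BT-549 cells (Homo sapiens) for cytotoxicity, read by MTT assay, with a stated time of 48 h (on this read-out lower numbers stand for stronger inhibition and higher numbers for weaker inhibition), compound 1 gives > 100000 nM, which is a limit of the assay rather than a number. Compound 2 gives > 100000 nM in this assay, also a limit. The step from compound 1 to compound 2 is therefore a step that the two limits leave unreadable from compound 1 to compound 2. Both values sit at the limit of > 100000 nM in this assay, at which 2 of the 2 values shown sit, so compound 2 stands at the limit with no number of its own.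

Compound 3, `COc1cccc(Nc2ncc3c(n2)N(C)CC(=O)N3)c1`, differs from compound 2 by methyl in place of hydrogen on a nitrogen on an aromatic ring in a ring. Among the compounds with values here, the only measured step that bears on it is the one from compound 1 to compound 2, and that step is unreadable, so no size or direction can be taken from it. Compound 3 is expected to give 100000 nM in this assay, within 30000 nM to 300000 nM, most probably again only as a limit. The expected step from compound 2 to compound 3 is thus a number no higher from compound 2 to compound 3 (the limit leaves the size open).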

Compound 3, half-maximal inhibitory concentration: > 100000 nM
Compound 3 was reported as a limit (the forecaster's own chance of this, stated with the estimate: 75%); the middle value sits exactly at the limit.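

In this assay compound 3 gives > 100000 nM, again a limit of the assay. No step can be read between compound 2 and compound 3, as both values are limits. The compounds shown leave open whether methoxy or methyl changes the read-out at all: the limit of > 100000 nM in this assay, at which 3 of the 3 values shown sit.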